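The compounds below may be only part of what the source reports. "The series", "measured", "known", "first", "only" and "open" are said of these compounds alone.

Measured in a functional assay on OVCAR-8 cells (Homo sapiens) for antiproliferative activity; a higher number here means a weaker inhibitor, a lower number a stronger inhibitor:
- compound 1 `CNC(=O)C[C@@H]1C[C@@H](c2ccc(Cl)c(Cl)c2)[C@H](NC(=O)c2cc(-c3c(Cl)cnn3C)c(Cl)o2)CN1`: 1130 nM
- compound 2 `Cn1ncc(Cl)c1-c1cc(C(=O)N[C@@H]2CN[C@H](CCN3CCC(O)CC3)C[C@H]2c2ccc(Cl)c(Cl)c2)oc1Cl`: 15900 nM
- compound 3 `Cn1ncc(Cl)c1-c1cc(C(=O)N[C@@H]2CN[C@H](CCCO)C[C@H]2c2ccc(Cl)c(Cl)c2)oc1Cl`: 600 nM

Compound 3 sits at the low end of these numbers, level with compound 1 within the scatter: a 1.9-fold lower number from compound 1 to compound 3 (0.27 log units; within the scatter). Compound 2 stands well apart from both.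

The next change leads to compound 4 `Cn1ncc(Cl)c1-c1cc(C(=O)N[C@@H]2CN[C@H](CCN3CCCCC3)C[C@H]2c2ccc(Cl)c(Cl)c2)oc1Cl`: piperidin-1-yl in place of hydroxymethyl on a saturated chain carbon, two bonds along the chain from a saturated ring carbon. In words, piperidin-1-yl comes in place of hydroxymethyl, on a saturated chain carbon, two bonds along the chain from a saturated ring carbon.

The closest evidence is the swap at this same place between 4-hydroxypiperidin-1-yl and hydroxymethyl, a large step: a 27-fold lower number from compound 2 to compound 3 (1.42 log units; beyond the scatter). The matching change from the methylcarbamoyl group of compound 1 is also large: a 14-fold higher number from compound 1 to compound 2 (1.15 log units; beyond the scatter). Both show a ring amine at the chain end going with a much higher number. Within the data shown here, only compound 2 carries such a ring, so this rests on one compound, and no measured compound has the plain piperidin-1-yl.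

Among the measured compounds shown here, a large step to a higher number in this assay is therefore expected, though perhaps smaller than the one seen with compound 2, and it is estimated as a 10-fold higher number from compound 3 to compound 4 (1.00 log units; beyond the scatter). For compound 4 the expected value is 6000 nM, with an estimated range of 1500 nM to 20000 nM.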

Compound 4, half-maximal inhibitory concentration: 1660 nM
For compound 4 the middle estimate is 3.6-fold (0.56 log units) above the measured one, within the range that was stated.
By their numbers in this assay, from the lowest: compounds 3, 1 and 4 (each within the scatter of the next, the first and the last beyond it); then compound 2.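

In this assay, a ring amine at the chain end does not on its own bring a large step: piperidin-1-yl in place of hydroxymethyl gives only a 2.8-fold higher number from compound 3 to compound 4 (0.44 log units; beyond the scatter) and so the large gap seen earlier cannot be read as a property of the ring alone. Most of that gap goes with the ring's hydroxy group, since hydrogen in place of hydroxy on a saturated ring carbon gives a 9.6-fold lower number from compound 2 to compound 4 (0.98 log units; beyond the scatter) in this one matched pair. Against the methylcarbamoyl group, (piperidin-1-yl)methyl gives a 1.5-fold higher number from compound 1 to compound 4 (0.17 log units; within the scatter) and leaves the plain ring level with that amide. No available evidence bears on this dependence on the hydroxy group.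

Still open, going by these compounds, is whether the high number of compound 2 is tied to a hydroxy group at that ring carbon, or would also appear with 3-hydroxypiperidin-1-yl, 4-methoxypiperidin-1-yl or morpholin-4-yl at the chain end. Open-chain groups such as dimethylamino, and a carboxylic acid at the same place, also remain to be placed against the plain piperidin-1-yl.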